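Changing the sulfonyl substituent at a cytotoxicity limit

The compounds below may be only part of what the source reports. "The series", "measured", "known", "first", "only" and "open" are said of these compounds alone.

In an ADME assay on HCT-116 cells (Homo sapiens) for cytotoxicity, read by CellTiter-Glo, with a stated time of 72 h (on this read-out lower numbers stand for stronger inhibition and higher numbers for weaker inhibition), compound 1 (`CC1CCN(C2CCN(S(=O)(=O)c3nccn3C)CC2)CC1`) gives > 10000 nM as a limit of the assay. Compound 2 (`Cc1nc(Cl)sc1S(=O)(=O)N1CCC(N2CCC(C)CC2)CC1`) gives > 10000 nM and that too is only a limit. Within the data shown here, the one measured step that bears on what follows is a step that the two limits leave unreadable from compound 1 to compound 2 and it has no readable size, with the limit of > 10000 nM in this assay, at which 2 of the 2 values shown sit, as the only evidence. Compound 3 (`CC1CCN(C2CCN(S(=O)(=O)c3ccc(Cl)c(Cl)c3)CC2)CC1`) differs by 3,4-dichlorophenyl in place of 2-chloro-4-methyl-1,3-thiazol-5-yl on a sulfonyl sulfur with 3,4-dichlorophenyl in place of 2-chloro-4-methyl-1,3-thiazol-5-yl on a sulfonyl sulfur. No direction is expected, so the estimated change in this assay is a number no higher from compound 2 to compound 3 (the limit leaves the size open) and stays within the scatter. Compound 3 is expected near 10000 nM and the estimated range runs from 3000 nM up to 30000 nM on this read-out.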

Compound 3, half-maximal inhibitory concentration: > 5000 nM
Compound 3 ended at the assay's limit (the forecaster's own chance of this, stated with the estimate: 70%); the middle value does not contradict the limit.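

Compound 3 gives > 5000 nM in this assay, and this is a limit of the assay. Among these compounds, no step among compound 1, compound 2 and compound 3 can be read. The compounds shown leave open whether the substituent on the sulfonyl sulfur changes this read-out at all.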